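Dropping the diamine side chain: what happens to cell toxicity

The source may hold more compounds than are shown below. What is called first, only, known or untested is meant among the compounds shown, and "the series" means these compounds.

Two compounds share a sugar core carrying two nine-carbon ether chains and have been measured in a toxicity assay on the whole organism (J774 cells) for cytotoxicity, with Mus musculus as the target, read by MTT assay, with a stated time of 24 h, tested at 30 uM; on this read-out higher numbers stand for a weaker effect at the one concentration tested and lower numbers for a stronger effect. Compound 1 `CCCCCCCCCO[C@@H]1[C@@H](N)[C@@H](OCC(O)CNCCN)O[C@H](CN)[C@H]1OCCCCCCCCC` gives 53% in this assay. Compound 2 `CCCCCCCCCO[C@@H]1[C@@H](N)[C@@H](OCC(O)CNCCCN)O[C@H](CN)[C@H]1OCCCCCCCCC` gives 71.6% in this assay, which is the higher of the two numbers and so the weaker effect. For the measured compounds named here, the only step measured so far, a number 18.6 percentage points higher from compound 1 to compound 2 (beyond the scatter), concerns a small lengthening of the outer amine chain.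

Compound 3 `C=CCO[C@H]1O[C@H](CN)[C@@H](OCCCCCCCCC)[C@H](OCCCCCCCCC)[C@H]1N` has not yet been measured in this assay. It differs from compound 2 by vinyl in place of 2-((3-aminopropyl)amino)-1-hydroxyethyl on a saturated chain carbon bound to an oxygen on a saturated carbon. Going by the values given here, this change removes the whole side chain that the measured step only lengthened, so that step does not bear on it directly, and no measured pair shows what removing this chain does. The expectation therefore rests mainly on the shared core. Compound 3 is expected to give about 68% in this assay, within a wide range from 40% to 95%. This means an expected step of a number 3.6 percentage points lower from compound 2 to compound 3 (within the scatter), likely within the scatter but with little confidence.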

Compound 3, a percentage reported as activity, at one concentration (the size of the read-out at that concentration, not a potency): 6.6%
For compound 3 the middle estimate is 61.4 percentage points above the measured one; measured number outside the range, below it.
By their numbers in this assay, from the lowest: compound 3; then compound 1; then compound 2.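

Replacing the whole side chain with vinyl, on a saturated chain carbon bound to an oxygen on a saturated carbon, gives large steps in this assay (a number 65 percentage points lower from compound 2 to compound 3 (beyond the scatter); a number 46.4 percentage points lower from compound 1 to compound 3 (beyond the scatter)), and on this read-out the lower number stands for a stronger effect. The side chain at this position therefore matters far more for this read-out than the earlier pair could show, since lengthening its outer amine chain produced only a modest step (a number 18.6 percentage points higher from compound 1 to compound 2 (beyond the scatter)). Nothing available here explains why the number falls so sharply when the side chain is replaced.

The change removes the hydroxyl group and the amine nitrogens together and also brings in a double bond, so the compounds shown cannot tell which of these differences accounts for the step. A propyl group in place of the allyl group would test the double bond, while a 2,3-dihydroxypropyl group or a 3-aminopropyl group on the same oxygen would separate the contribution of the hydroxyl groups from that of an amine.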